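The compounds below may be only part of what the source reports. "The series", "measured", "known", "first", "only" and "open" are said of these compounds alone.

Compound 1 `COC(=O)N[C@H]1Cc2ccc(NC(=O)c3ccccc3-c3ccc(C(F)(F)F)cc3)cc2C1` is the starting point of this small set. In an assay for inhibition of apolipoprotein B-100 (Homo sapiens), tested at 100 nM (a higher number here means a weaker inhibitor, a lower number a stronger inhibitor), compound 1 gives 1.9 nM. Compound 2 `COC(=O)N[C@H]1Cc2ccc(NC(=O)c3cc(C)ccc3-c3ccc(C(F)(F)F)cc3)cc2C1` differs from it by a single change, (methyl in place of hydrogen on an aromatic carbon). In this assay compound 2 gives 2.2 nM, and the step of a 1.2-fold higher number from compound 1 to compound 2 (0.06 log units; within the scatter) stays within the usual scatter of repeated measurements.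

Compound 3 `COC(=O)NC1CCc2ccc(NC(=O)c3cccc(C)c3-c3ccc(C(F)(F)F)cc3)cc2CC1` carries the same amide and the same 4-(trifluoromethyl)phenyl group but on a different core; the difference between the two cores is not broken down here. In this assay compound 3 gives 1.6 nM. The values of compound 3 and compound 1 lie within the scatter of each other, as do those of compound 3 and compound 2.

Compound 4 `COC(=O)NC1CCc2ccc(NC(=O)c3cc(C)cc(C)c3-c3ccc(C(F)(F)F)cc3)cc2CC1` has not yet been measured. It differs from compound 3 by methyl in place of hydrogen on an aromatic carbon. Among the compounds with values here, the place is not quite the one seen before: in compound 4 the entering methyl is also meta to a methyl group (1 heavy atom), so this is the same kind of change as the one from compound 1 to compound 2, not the same change. The earlier step of a 1.2-fold higher number from compound 1 to compound 2 (0.06 log units; within the scatter) stayed within the scatter. On that basis the expected step is a 1.2-fold higher number from compound 3 to compound 4 (0.07 log units; within the scatter). Compound 4 is therefore estimated at 1.9 nM, with a likely range from 1 nM to 3.6 nM.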

Compound 4, half-maximal inhibitory concentration: 2.4 nM
Compound 4: middle estimate off by 1.3-fold (0.10 log units), on the low side, within the range that was stated.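

In this assay, a methyl in place of hydrogen on an aromatic carbon gives a 1.5-fold higher number from compound 3 to compound 4 (0.18 log units; within the scatter), so on this core the change leaves no readable mark on the number. Set beside the earlier step, the change looks much the same on both cores, as far as this assay can tell: the same change on two cores in this assay, a 1.2-fold higher number (0.06 log units; within the scatter) from compound 1 to compound 2 and a 1.5-fold higher number (0.18 log units; within the scatter) from compound 3 to compound 4, 1.3-fold (0.11 log units) apart, within the scatter of two such steps This shows that the change can be carried from one core to the other here without a step beyond the usual scatter, but it rests on only two pairs and does not show that the two cores respond identically: a small real difference between them would be hidden in the scatter, and the two places are not quite the same, as in compound 4 the entering methyl is also meta to a methyl group.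

The compounds shown carry only hydrogen or methyl at these places on the ring, which leaves open whether a chlorine atom, a methoxy group or a longer chain such as ethyl would move the number beyond the scatter. Also open, as far as these compounds go, is whether the same small step would hold on a third core, or for a methyl placed elsewhere on this ring.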